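This account rests on a few compounds, and the source may have more. Where it says the series, first, only, none or still open, it means among the compounds named here.

Measured so far:
compound 1 `CCOCCOc1cccc2ccc(N)nc12` — > 2000 nM (a limit)
compound 2 `CCC(C)COc1cccc2ccc(N)nc12` — 36 nM

In an assay on cells with melanin-concentrating hormone receptor 1 (Homo sapiens) as the target, read by radioligand binding (a higher number here means a weaker inhibitor, a lower number a stronger inhibitor), compound 1 gives only a limit, > 2000 nM. Among the measured compounds shown here, compound 2 gives 36 nM, the only plain number so far; the other value sits at the limit of > 2000 nM in this assay, at which 1 of the 2 values shown sits. For the measured compounds named here, the one measured step, an at least 55-fold lower number from compound 1 to compound 2 (1.74 log units; beyond the scatter), is large and beyond the scatter.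

Compound 3 `CC#CCCOc1cccc2ccc(N)nc12` differs from compound 2 by but-2-yn-1-yl in place of sec-butyl on a saturated chain carbon bound to an oxygen on an aromatic ring. That measured step touched the same place and shows the chain there matters, but neither end of it matches but-2-yn-1-yl, so it sets no clear size. A moderate step is expected, a 2.8-fold higher number from compound 2 to compound 3 (0.44 log units; beyond the scatter), likely toward a higher number. Compound 3 is estimated at 100 nM, within 20 nM to 600 nM.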

Compound 3, half-maximal inhibitory concentration: > 2000 nM
Compound 3 ended at the assay's limit; the forecaster's own chance of this, stated with the estimate: 10%; at least 20-fold (1.30 log units) between middle value and limit.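

At this position, on a saturated chain carbon bound to an oxygen on an aromatic ring, but-2-yn-1-yl in place of sec-butyl gives an at least 55-fold higher number from compound 2 to compound 3 (1.74 log units; beyond the scatter) in this assay, with the count of 4 heavy atoms unchanged. An all-carbon group of this count is therefore not enough to hold the number of compound 2. Compound 1 and compound 3 both stand at a limit, so the step between them cannot be read: the limit of > 2000 nM in this assay, at which 2 of the 3 values shown sit.

Still open, from the compounds shown here alone, is whether the triple bond or the lost branch carries this change, as both differ in this step. A straight butyl chain at this position would separate the two.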